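The compounds below may be only part of what the source reports. "The series", "measured", "known", "first", "only" and "open" are said of these compounds alone.

Among the compounds with values here, the two compounds measured so far share one core. Compound 1, `CC(=O)C1=C(C)NC(=O)NC1c1ccsc1`, carries thiophen-3-yl on the core, while compound 2, `CCNC(=O)C1=C(C)NC(=O)NC1c1ccoc1`, carries furan-3-yl there and an ethylcarbamoyl group. In an assay on membranes from CHO cells for displacement of a labelled ligand from adenosine receptor A1 (Homo sapiens), read by scintillation counting, with a stated time of 60 min, tested at 1 uM (a higher number here means more inhibition at the concentration tested (going by the name of the read-out), a lower number less inhibition), compound 1 gives 9%, and in this assay compound 2 gives 1%. Compound 2 thus stands alongside compound 1: the gap between the two numbers lies within the usual scatter of repeated measurements, so the two numbers are level. Compound 3, `CCNC(=O)C1=C(C)NC(=O)NC1c1ccsc1`, has not yet been measured. It differs from compound 2 in one place: thiophen-3-yl in place of furan-3-yl on a saturated ring carbon. Within the data shown here, no step between two measured compounds isolates this exchange on its own. Both measured values are low and lie within scatter of each other. The expected step, a number 4 percentage points higher from compound 2 to compound 3 (within the scatter), is therefore small, with no direction beyond the scatter. Compound 3 is estimated at 5%, within a range from -5% to 15%.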

Compound 3, a percentage reported as inhibition, at one concentration (the size of the read-out at that concentration, not a potency): 3%
Compound 3: middle estimate off by 2 percentage points, on the high side; the range from low to high includes it.
By their numbers in this assay, from the lowest: compounds 2, 3 and 1 (each within the scatter of the next).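

Within the data shown here, compound 3 gives the first single-place reading of thiophen-3-yl in place of furan-3-yl on a saturated ring carbon: in this assay the exchange gives a number 2 percentage points higher from compound 2 to compound 3 (within the scatter) with the ethylcarbamoyl group held constant. Among these compounds, it also gives the first single-place reading at the carbonyl carbon, with a number 6 percentage points lower from compound 1 to compound 3 (within the scatter) when ethylamino stands in place of methyl. Neither exchange separates its pair of compounds beyond the scatter, and nothing available here accounts for these numbers.

Going by these compounds, all three compounds carry a five-membered aromatic ring with one hetero atom on the saturated ring carbon, so it remains open whether a phenyl ring there would give a number beyond the scatter. On these data alone, it also remains open whether a carboxylic acid or a longer chain on the carbonyl carbon would do so.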